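This account rests on a few compounds, and the source may have more. Where it says the series, first, only, none or still open, it means among the compounds named here.

Working notes on the series. The compounds share one core and differ in the side chain that carries the hydroxyl-bearing quaternary carbon. Compound 1 `COC(=O)CC/C=C\CC[C@H]1C(=O)C[C@@H](O)[C@@H]1/C=C/C[C@@](C)(O)/C=C/C1=CCCC1` gives in a functional assay on the whole organism (stomach) with Canis familiaris (Canis lupus familiaris) as the target (on this read-out higher numbers stand for an effect only at larger amounts of compound and lower numbers for an effect already at smaller amounts), a value of 0.00002 mg/kg, the lowest of the three numbers in hand. Compound 2 `COC(=O)CC/C=C\CC[C@H]1C(=O)C[C@@H](O)[C@@H]1/C=C/CC(C)(O)CCC1CCC1` gives 0.00009 mg/kg in this assay, and compound 3 `COC(=O)CC/C=C\CC[C@H]1C(=O)C[C@@H](O)[C@@H]1/C=C/CC(C)(O)CCC1=CCCC1` gives 0.0001 mg/kg in this assay. The two steps away from compound 1 go a 4.5-fold higher number from compound 1 to compound 2 (0.65 log units; beyond the scatter) and a 5.0-fold higher number from compound 1 to compound 3 (0.70 log units; beyond the scatter); both replace the prop-2-en-1-yl chain by a saturated propyl while also changing the terminal ring, so neither isolates the ring alone. The step of a 1.1-fold higher number from compound 2 to compound 3 (0.05 log units; within the scatter) does isolate a ring exchange at the chain end and stays within the scatter.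

Compound 4 `COC(=O)CC/C=C\CC[C@H]1C(=O)C[C@@H](O)[C@@H]1/C=C/C[C@@](C)(O)/C=C/C1(C)CC1` is not yet measured. It differs from compound 1 as follows (1-methylcyclopropyl in place of cyclopent-1-en-1-yl on a double-bonded chain carbon bound to a double-bonded chain carbon). The prop-2-en-1-yl chain and the hydroxy group of compound 1 are kept; only the terminal ring is exchanged. On the evidence of compound 2 against compound 3, a ring exchange at that end is expected to move the number little, so the expected step is a 1.5-fold higher number from compound 1 to compound 4 (0.18 log units; within the scatter) in this assay. Compound 4 is estimated at 0.00003 mg/kg in this assay, with a range of 0.00001 mg/kg to 0.0001 mg/kg.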

Compound 4, dose for half-maximal effect: 0.00002 mg/kg
Compound 4: the middle estimate sits 1.5-fold (0.18 log units) above what was measured; low and high end bracket the measured number.
By their numbers in this assay, from the lowest: compounds 1 and 4 (each within the scatter of the next); then compounds 2 and 3 (each within the scatter of the next).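

With the prop-2-en-1-yl chain and the hydroxy group kept, 1-methylcyclopropyl in place of cyclopent-1-en-1-yl gives no change at the digits printed from compound 1 to compound 4 (within the scatter) in this assay: on the unsaturated chain, as on the saturated one, this ring exchange leaves the number within the scatter, and the ring double bond of compound 1 is not needed to hold it. The steps of a 5.0-fold lower number from compound 3 to compound 4 (0.70 log units; beyond the scatter) and a 4.5-fold lower number from compound 2 to compound 4 (0.65 log units; beyond the scatter) change chain and ring together, yet they match in size the chain change alone, a 5.0-fold higher number from compound 1 to compound 3 (0.70 log units; beyond the scatter). The data at hand offer no explanation for any of these steps.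

Still open, going by these compounds, is whether 1-methylcyclopropyl on the saturated chain would give the same number as the rings of compound 2 and compound 3. Also open, on these data alone, is how far the position accepts a phenyl ring, a terminal amine or a longer chain.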